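The compounds below may be only part of what the source reports. "The series", "measured", "known", "first", "only" and "open" are said of these compounds alone.

Measured in a functional assay on SK-BR-3 cells (Homo sapiens) for antiproliferative activity; a higher number here means a weaker inhibitor, a lower number a stronger inhibitor:
- compound 1 `CCN(CC)CCCOc1ccc2cc(NC(=O)c3ccc(O)c(CC=C(C)C)c3)c(=O)oc2c1C`: 4900 nM
- compound 2 `CCCNCCCOc1ccc2cc(NC(=O)c3ccc(O)c(CC=C(C)C)c3)c(=O)oc2c1C`: 990 nM
- compound 3 `CC(C)=CCc1cc(C(=O)Nc2cc3ccc(OCCCN(C(C)C)C(C)C)c(C)c3oc2=O)ccc1O`: 1600 nM

In this assay, compound 3 at 1600 nM stands clearly apart from compound 1, with a 3.1-fold lower number from compound 1 to compound 3 (0.49 log units; beyond the scatter). It cannot be separated from compound 2, since a 1.6-fold higher number from compound 2 to compound 3 (0.21 log units; within the scatter) does not exceed ordinary repeat variation.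

The next compound is compound 4 `CC(C)=CCc1cc(C(=O)Nc2cc3ccc(OCCCNCCO)c(C)c3oc2=O)ccc1O`. It keeps the shared core and changes only the amine: (2-hydroxyethyl)amino in place of diisopropylamino on a saturated chain carbon, three bonds along the chain from an oxygen on an aromatic ring. The count of that change is (2-hydroxyethyl)amino in place of diisopropylamino on a saturated chain carbon, three bonds along the chain from an oxygen on an aromatic ring.

All three measured steps alter the amine at this same place. Two were modest, a 4.9-fold lower number from compound 1 to compound 2 (0.69 log units; beyond the scatter) and a 3.1-fold lower number from compound 1 to compound 3 (0.49 log units; beyond the scatter), and the third, a 1.6-fold higher number from compound 2 to compound 3 (0.21 log units; within the scatter), was within the scatter. Going by the values given here, no measured compound carries a hydroxyethyl group, so this estimate is uncertain. The closest guide by name is the propylamino group of compound 2, at 990 nM.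

The estimated change is a 1.2-fold lower number from compound 3 to compound 4 (0.09 log units; within the scatter), so no step beyond the scatter is expected in this assay. The expected value for compound 4 is 1300 nM, within an estimated range of 450 nM to 4000 nM.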

Compound 4, half-maximal inhibitory concentration: 610 nM
For compound 4 the middle estimate is 2.1-fold (0.33 log units) above the measured one, within the range that was stated.
By their numbers in this assay, from the lowest: compounds 4, 2 and 3 (each within the scatter of the next, the first and the last beyond it); then compound 1.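

In this assay, a hydroxy group on the amine chain is accepted at this position: putting (2-hydroxyethyl)amino in place of diisopropylamino gives a 2.6-fold lower number from compound 3 to compound 4 (0.42 log units; beyond the scatter) and putting it in place of diethylamino gives an 8.0-fold lower number from compound 1 to compound 4 (0.90 log units; beyond the scatter), the largest step seen so far among these amines. Hydroxy in place of methyl, on a saturated chain carbon two bonds along the chain from an amine nitrogen, gives a 1.6-fold lower number from compound 2 to compound 4 (0.21 log units; within the scatter), so this swap at the chain end cannot be told apart from no change. Compound 2 and compound 4, each with a single chain on the amine nitrogen, both lie clear of compound 1, but compound 3 goes against any simple split by chain count, since it has two chains on that nitrogen and still lies clear of compound 1 and within the scatter of compound 2.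

Still open, on these data alone, is whether a methoxy group in place of the hydroxy, a carboxylic acid at the chain end, or a longer chain between the amine nitrogen and the hydroxy would keep this level of activity. Nothing shown here accounts for the differences among these amines.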